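The source may report more compounds than this note shows. Statements on the series, on what has been measured and on what is new or still open speak of the compounds shown alone.

Working notes on the series. Of the compounds shown here, two carry numbers so far. Compound 1 `COc1n[nH]c2ncc(C#Cc3c(F)ccc(NS(=O)(=O)c4cccc(Cl)c4)c3F)cc12` and compound 2 `COc1n[nH]c2ncc(-c3cn(-c4c(F)ccc(NS(=O)(=O)c5ccccc5)c4F)nn3)cc12` share the core and the difluorinated aryl sulfonamide but differ in the linker and in the sulfonyl ring. In an assay on Sf9 cells for inhibition of mitogen-activated protein kinase kinase kinase 20 (Homo sapiens), read by ADP-Glo, with a stated time of 30 min (on this read-out higher numbers stand for weaker inhibition and lower numbers for stronger inhibition), compound 1 gives 14.7 nM. In this assay compound 2 gives 3.8 nM, the lower of the two numbers; the gap to compound 1 lies beyond the scatter. As the two compounds differ in more than one place, no single step can be read from them.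

Compound 3 `COc1n[nH]c2ncc(-c3cn(-c4c(F)ccc(NS(=O)(=O)c5cccc(C(C)C)c5)c4F)nn3)cc12` is the next member and differs from compound 2 in one place: isopropyl in place of hydrogen on an aromatic carbon. Among the measured compounds shown here, no measured pair isolates this change, so there is no direct precedent for its effect. The expectation is a step no larger than the scatter, in either direction, so that compound 3 is estimated to land close to compound 2, as a 1.2-fold higher number from compound 2 to compound 3 (0.07 log units; within the scatter). For compound 3 in this assay the estimate is 4.5 nM, with a range from 1.5 nM to 14 nM.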

Compound 3, half-maximal inhibitory concentration: 6.9 nM
Compound 3: the middle estimate sits 1.5-fold (0.19 log units) below what was measured, and the stated range covers the measured number.
By their numbers in this assay, from the lowest: compounds 2 and 3 (each within the scatter of the next); then compound 1.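

In this assay, among the compounds shown here, the first single-place comparison, isopropyl in place of hydrogen on an aromatic carbon, read as phenyl to 3-isopropylphenyl, gives a 1.8-fold higher number from compound 2 to compound 3 (0.26 log units; within the scatter) on the sulfonyl ring. This carbon of the ring therefore carries a group of 3 heavy atoms, with no ring and no hydrogen-bond donors or acceptors, with a step that cannot be told from the scatter. Nothing measured here speaks to why the step has this size.

From the compounds shown here alone, whether the same holds for an amine, a carboxylic acid or a longer chain at this carbon remains open. For the compounds shown here, also open is whether isopropyl on this ring gives a similar step with the linker of compound 1 in place of the one shared by compound 2 and compound 3.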